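A few compounds are considered here, and "the series" means these few. Any claim that something is new, unique, unknown or untested is made for them only; others in the source may bear on it.

Measured so far in a functional assay on HL-60 cells (Homo sapiens) for cytotoxicity, read by WST assay, with a stated time of 48 h; a lower number here means that less compound is needed, a higher number that more compound is needed for the effect:
compound 1 `O=C1OC[C@H](Cc2ccccc2)[C@H]1Cc1ccc(Cl)c(Cl)c1` gives 19000 nM
compound 2 `O=C1OC[C@H](Cc2ccc(O)cc2)[C@H]1Cc1ccc(Cl)c(Cl)c1` gives 37000 nM
compound 3 `COc1ccc(C[C@H]2COC[C@@H]2Cc2ccc(Cl)c(Cl)c2)cc1` gives 39000 nM

Compound 1 and compound 2 share a core and differ only by hydroxy in place of hydrogen on an aromatic carbon. That change made a 1.9-fold higher number from compound 1 to compound 2 (0.29 log units; within the scatter). Compound 3 has a different core; the difference between the two cores is not broken down here. Compound 4 `COc1ccc(C[C@H]2COC[C@@H]2Cc2ccc(Cl)c(Cl)c2)cc1O` arises from compound 3 by hydroxy in place of hydrogen on an aromatic carbon. Going by the values given here, this is the same kind of change as the one from compound 1 to compound 2, but not the same: in compound 2 the hydroxy sits para to a large group, whereas in compound 4 it sits ortho to a methoxy group and meta to a large group. Among the compounds with values here, with only one prior example, the step from compound 3 to compound 4 in this assay is expected to be about a 1.5-fold higher number from compound 3 to compound 4 (0.19 log units; within the scatter), because the earlier change gave a 1.9-fold higher number from compound 1 to compound 2 (0.29 log units; within the scatter). Compound 4 is therefore estimated at 60000 nM, with a likely range from 28000 nM to 130000 nM.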

Compound 4, half-maximal effective concentration: 33000 nM
The estimate for compound 4 lay 1.8-fold (0.26 log units) above the measured number; measured number inside the range.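

In this assay, hydroxy in place of hydrogen on an aromatic carbon gave a 1.2-fold lower number from compound 3 to compound 4 (0.07 log units; within the scatter), a step too small to count as a real change. Set beside the earlier step, the two results agree as far as this assay can tell: the same change on two cores in this assay, a 1.9-fold higher number (0.29 log units; within the scatter) from compound 1 to compound 2 and a 1.2-fold lower number (0.07 log units; within the scatter) from compound 3 to compound 4, 2.3-fold (0.36 log units) apart, within the scatter of two such steps. The change therefore made no clear difference on either core, but two pairs with the hydroxy at different ring positions do not show how it would behave on other cores or at other positions.

On these data alone, whether another group on this ring, such as an amine or a carboxylic acid, would move the number beyond the scatter remains open. Also open is what the core alone contributes: no pair shown differs only there.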